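This account rests on a few compounds, and the source may have more. Where it says the series, first, only, none or still open, it means among the compounds named here.

In a functional assay on the whole organism for inhibition, with Rattus norvegicus as the target, read by paw edema, with a stated time of 4 h, at a dose of 70 mg/kg by the oral route (a lower number here means less inhibition, a higher number more inhibition at the dose given (going by the name of the read-out)), compound 1 `Cc1ccccc1-c1nn2c(-c3ccncc3)nnc2s1` gives 79.8%. Compound 2 `CC(=O)Oc1ccccc1-c1nn2c(-c3ccncc3)nnc2s1` carries a change on the carbon-only ring, acetoxy in place of methyl on an aromatic carbon and in this assay compound 2 gives 39.8%, so that a number 40 percentage points lower from compound 1 to compound 2 (beyond the scatter). Compound 3 `Cc1ccccc1-c1nnc(-c2ccncc2)o1` has a different core; the difference between the two cores is not broken down here. In this assay compound 3 gives 43.4%. Compound 4 `CC(=O)Oc1ccccc1-c1nnc(-c2ccncc2)o1` is compound 3 with the same change, (acetoxy in place of methyl on an aromatic carbon). The step from compound 3 to compound 4 is expected to be a drop, a number 28.4 percentage points lower from compound 3 to compound 4 (beyond the scatter), smaller than the earlier one because compound 3 at 43.4% leaves less room to fall. The estimate for compound 4 in this assay is 15%, expected between 0% and 35%.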

Compound 4, a percentage reported as inhibition, in the whole organism at one dose (the size of the read-out at that dose, not a potency): 63.4%
Compound 4: the middle estimate sits 48.4 percentage points below what was measured, and the stated range ends below it.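

In this assay, acetoxy in place of methyl gives a number 20 percentage points higher from compound 3 to compound 4 (beyond the scatter), so the change that lowered the number on the core of compound 1 raises it on the core of compound 3. Within the data shown here, the result of this change therefore does not carry from one core to the other, not even in direction: the same change on two cores in this assay, a number 40 percentage points lower (beyond the scatter) from compound 1 to compound 2 and a number 20 percentage points higher (beyond the scatter) from compound 3 to compound 4, 60 percentage points apart, beyond the scatter of two such steps With only one pair on each core, tested at a single dose, this shows that the outcome depends on the core, but not which feature of either core is responsible. The compounds shown leave open how a hydroxyl, a methoxy or an amine in the same place would behave on each core. They also leave open whether a longer ester, such as propionyloxy, would follow acetoxy.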